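Shikonin Esters Against DU-145 Cells: Extending the Alkyl Chain

This account rests on a few compounds, and the source may have more. Where it says the series, first, only, none or still open, it means among the compounds named here.

Measured compounds:
compound 1 `CC[C@](C)(O)CC(=O)O[C@H](CC=C(C)C)C1=CC(=O)c2c(O)ccc(O)c2C1=O` gives 20500 nM in a functional assay on DU-145 cells (Homo sapiens) for cytotoxicity, read by MTT assay; a higher number here means a weaker inhibitor, a lower number a stronger inhibitor;
compound 2 `CC(C)=CC[C@@H](OC(=O)C1CCCOC1)C1=CC(=O)c2c(O)ccc(O)c2C1=O` gives 29700 nM;
compound 3 `CC(C)=CC[C@@H](OC(=O)CC(O)c1ccccc1)C1=CC(=O)c2c(O)ccc(O)c2C1=O` gives 17000 nM.

Among the compounds with values here, compound 3 gives the lowest of the three numbers, but its neighbours sit close: a 1.2-fold lower number from compound 1 to compound 3 (0.08 log units; within the scatter) and a 1.7-fold lower number from compound 2 to compound 3 (0.24 log units; within the scatter), so no compound can be called stronger than another. Compound 4 `CCCCCCC(C)(O)CC(=O)O[C@H](CC=C(C)C)C1=CC(=O)c2c(O)ccc(O)c2C1=O` differs from compound 3 in one place: 1-hydroxy-1-methylheptyl in place of hydroxy(phenyl)methyl on a saturated chain carbon bound to a carbonyl carbon. The most relevant comparison is compound 1, which already carries a 1-hydroxy-1-methylpropyl at the same place, and a 1.2-fold lower number from compound 1 to compound 3 (0.08 log units; within the scatter) was small. Within the data shown here, compound 4 only lengthens that chain, and no measured step tests such an extension. A step within the scatter is therefore expected, a 1.1-fold lower number from compound 3 to compound 4 (0.03 log units; within the scatter), and compound 4 is estimated at 16000 nM, between 6000 nM and 42000 nM.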

Compound 4, half-maximal inhibitory concentration: > 100000 nM
Compound 4: a limit, no number; the forecaster's own chance of this, stated with the estimate: 5%; at least 6.2-fold (0.79 log units) between middle value and limit.
By their numbers in this assay, from the lowest: compounds 3, 1 and 2 (each within the scatter of the next). At a limit, above all of these: compound 4.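

Compound 4 gives a limit, not a number, in this assay: the limit of > 100000 nM in this assay, at which 1 of the 4 values shown sits.

Lengthening 1-hydroxy-1-methylpropyl to 1-hydroxy-1-methylheptyl gives an at least 4.8-fold higher number from compound 1 to compound 4 (0.68 log units; beyond the scatter), so this place does not accept every group, which the earlier compounds, all within the scatter of one another, could not show. The other comparisons agree, with an at least 5.8-fold higher number from compound 3 to compound 4 (0.76 log units; beyond the scatter) and an at least 3.3-fold higher number from compound 2 to compound 4 (0.52 log units; beyond the scatter).

No intermediate chain such as 1-hydroxy-1-methylbutyl is among the compounds shown, so where the number starts to climb stays open. From the compounds shown here alone, how an amine at this place would read also stays open.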